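A few compounds are considered here, and "the series" means these few. Any claim that something is new, unique, unknown or untested is made for them only; others in the source may bear on it.

Measured so far:
compound 1 `CCCCCCNC(=O)/C=C/c1ccccc1` – 82%
compound 2 `CCCCCCCCCCNC(=O)/C=C/c1ccccc1` – 15%

In a functional assay on the whole organism for inhibition, with Brassica rapa subsp. chinensis as the target, with a stated time of 3 days, tested at 100 ppm (on this read-out lower numbers stand for less inhibition of growth and higher numbers for more inhibition of growth at the one concentration tested), compound 1 gives 82%, whereas compound 2 gives 15%. Among the measured compounds shown here, compound 2 therefore stands lowest of the two numbers measured, with compound 1 as its only neighbour well apart from it. For the measured compounds named here, the single measured step, a number 67 percentage points lower from compound 1 to compound 2 (beyond the scatter), corresponds to butyl in place of hydrogen on a saturated chain carbon, six bonds along the chain from an amide-type nitrogen.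

Compound 3 `CCCCCCCCNC(=O)/C=C/c1ccccc1` has not yet been measured. It differs from compound 2 by hydrogen in place of ethyl on a saturated chain carbon, eight bonds along the chain from an amide-type nitrogen, so compound 3 carries a chain shorter than that of compound 2 and longer than that of compound 1. The step that bears on it is the one already seen, a number 67 percentage points lower from compound 1 to compound 2 (beyond the scatter), which was large and downward on lengthening the chain. Reversing part of that lengthening is expected to bring the number part of the way back up, and the expected step is a number 35 percentage points higher from compound 2 to compound 3 (beyond the scatter) in this assay. For compound 3 an estimate of 50% is made, expected to lie between 20% and 80%.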

Compound 3, percent growth inhibition at one concentration: 42%
Compound 3: middle estimate off by 8 percentage points, on the high side; measured number inside the range.
By their numbers in this assay, from the lowest: compound 2; then compound 3; then compound 1.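

In this assay the carbon eight bonds along the chain from an amide-type nitrogen proves to count on its own: hydrogen in place of ethyl there gives a number 27 percentage points higher from compound 2 to compound 3 (beyond the scatter), so only part of the earlier loss is recovered. The matching change closer in gives a number 40 percentage points lower from compound 1 to compound 3 (beyond the scatter), which shows that much of the loss has already occurred at the chain length of compound 3. Among these three compounds the number falls with each lengthening of the chain, and none goes against this; compound 3 stands clearly apart from both of the others, so the fall runs in stages over this range and is not a single drop at one chain length.

Still open, as far as these compounds go, is whether a chain shorter than that of compound 1 would raise the number further or lower it, and what an amine or a carboxylic acid on the chain would do. No measurement at hand bears on why the number moves with chain length.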